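This account rests on a few compounds, and the source may have more. Where it says the series, first, only, none or still open, it means among the compounds named here.

In a physicochemical assay for acid dissociation, compound 1 (`O=C1C(Cl)=C(Nc2ccc(S(=O)(=O)Nc3nccs3)cc2)C(=O)c2ccccc21`) gives < 7.91 as a limit and not a number. Compound 2 (`Cc1cc(NS(=O)(=O)c2ccc(NC3=C(Cl)C(=O)c4ccccc4C3=O)cc2)no1`) gives < 7.91 and this too is only a limit. Going by the values given here, the evidence is thus the limit of < 7.91 in this assay, at which 2 of the 2 values shown sit, and the sole measured step is a step that the two limits leave unreadable from compound 1 to compound 2 with no size to carry forward. Compound 3 (`Cc1noc(NS(=O)(=O)c2ccc(NC3=C(Cl)C(=O)c4ccccc4C3=O)cc2)c1C`) has 3,4-dimethyl-1,2-oxazol-5-yl in place of 5-methyl-1,2-oxazol-3-yl on a sulfonamide nitrogen. Only a loose expectation is possible, an estimated step that the limit leaves unreadable from compound 2 to compound 3 in this assay with its direction unsupported by any measured step. For compound 3 the expected value is 6.5 within an estimated range of 5 to 7.9 in this rough forecast.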

Compound 3, acid dissociation constant: < 7.91
Compound 3: a limit, no number; the forecaster's own chance of this, stated with the estimate: 70%; the middle value is on the limit's open side.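

Going by these compounds alone, compound 1, compound 2 and compound 3 all stand only as limits in this assay, so no step among them can be read. The compounds shown leave open each compound's actual acid dissociation constant, and whether changing the group on the sulfonamide nitrogen shifts it at all.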